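This account rests on a few compounds, and the source may have more. Where it says the series, first, only, none or still open, it means among the compounds named here.

Measured compounds:
- compound 1 `N#Cc1ccc(N2CCc3cc(-c4cnc5ccccc5c4)ccc3C2)cc1C(F)(F)F` — "not determined" (no result reported) in an ADME assay on L02 cells (Homo sapiens) for antiproliferative activity, read by CCK-8 assay, with a stated time of 6 days; on this read-out higher numbers stand for weaker inhibition and lower numbers for stronger inhibition
- compound 2 `CCN(c1ccc(C#N)c(Cl)c1)c1cc(-c2cccnc2)ccc1C` — 12700 nM
- compound 3 `N#Cc1ccc(N2CCc3cc(-c4cncnc4)ccc3C2)cc1C(F)(F)F` — "not determined" (no result reported)

Within the data shown here, compound 2 carries the only number in this assay; compound 1 and compound 3 stand without a figure, so nothing can be said of how they compare to it or to each other. Among the measured compounds shown here, compound 2 therefore is the sole reference point, and no step between measured compounds is available to show how any change moves the read-out.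

The next compound, compound 4 `CCN(c1ccc(C#N)c(Cl)c1)c1cc(-c2ccnn2C)ccc1C`, differs from compound 2 in one place: 1-methyl-1H-pyrazol-5-yl in place of pyridin-3-yl on an aromatic carbon. The change swaps one aromatic ring for another of the same heavy-atom count at the same position, on an aromatic carbon of a six-membered aromatic ring of carbon only. For the measured compounds named here, with no measured step to lean on, the working assumption is a step of no size beyond the usual scatter in this assay, in no preferred direction.

On that basis compound 4 is expected to come in near compound 2, at an estimated 12000 nM with a range of 5000 nM to 30000 nM, which would be an estimated step of a 1.1-fold lower number from compound 2 to compound 4 (0.02 log units; within the scatter).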

Compound 4, half-maximal inhibitory concentration: 6230 nM
Beside the measured number, compound 4's estimate is 1.9-fold (0.28 log units) above it; the measured number falls inside the stated range.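

In this assay, this position gives the first readable response to a change in the series: replacing pyridin-3-yl with 1-methyl-1H-pyrazol-5-yl gives a 2.0-fold lower number from compound 2 to compound 4 (0.31 log units; beyond the scatter). The step is modest, but it shows that the read-out on this aromatic carbon, para to a methyl group, can move when one aromatic ring of the same heavy-atom count replaces another, and that the five-membered ring with 2 hetero atoms gives the lower number. No supporting data bear on the reason for this step.

As far as these compounds go, this single swap changes ring size, hetero atom count and the methyl group together, so their separate contributions remain open. Also open, from the compounds shown here alone, is how a non-aromatic substituent on this carbon, such as a primary amine or a carboxylic acid, would read.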